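A few compounds are considered here, and "the series" means these few. Any claim that something is new, unique, unknown or untested is made for them only; others in the source may bear on it.

Working notes on the series.

For the measured compounds named here, compound 1 `CC(C)C(/C=C1\CCNC1=O)c1ccc(-c2ccc3cccc(F)c3c2)[nH]c1=O` stands lowest of the three numbers so far in an assay on CHO cells for displacement of a labelled ligand from prostaglandin E2 receptor EP3 subtype (Homo sapiens), read by radioligand binding; a lower number here means a stronger inhibitor, a higher number a weaker inhibitor: compound 1 gives 2.2 nM. The two compounds that carry a triazolyl group on the branched chain carbon both sit higher, and in each case the gap to compound 1 is beyond the scatter: compound 2 `CCC(CC)(c1nnc[nH]1)c1ccc(-c2ccc3cccc(F)c3c2)[nH]c1=O` gives 19 nM and compound 3 `CCn1ncc2c(F)cc(-c3ccc(C(CC)(CC)c4nnc[nH]4)c(=O)[nH]3)cc21` gives 17 nM. Going by the values given here, no single-change step between measured compounds is available, so these are values side by side, not a computed step.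

Compound 4 `CC(C)C(Nc1nnc[nH]1)c1ccc(-c2ccc3cccc(F)c3c2)[nH]c1=O` has not been measured. It differs from compound 1 in one place: a group of 6 heavy atoms (2 carbon, 4 nitrogen; one five-membered aromatic ring with 3 hetero atoms) in place of a group of 7 heavy atoms (5 carbon, 1 nitrogen, 1 oxygen; one five-membered non-aromatic ring with 1 hetero atom), on a saturated chain carbon bound to an aromatic carbon and a saturated chain carbon. The entering group is again a triazole, here joined through an amino nitrogen, while the leaving group is the only one in the series that holds a non-aromatic ring.

Expectation: the triazole-bearing compound 2 shows 19 nM, and the likewise triazole-bearing compound 3 shows 17 nM, both against the lower number of compound 1. On that basis a step upward from compound 1 to compound 4 is expected, of a size beyond the scatter but short of the gap to compound 2. The expected step is a 4.1-fold higher number from compound 1 to compound 4 (0.61 log units; beyond the scatter). Compound 4 is estimated at 9 nM in this assay, within a range from 3 nM to 30 nM.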

Compound 4, inhibition constant: 22 nM
For compound 4 the middle estimate is 2.4-fold (0.39 log units) below the measured one; low and high end bracket the measured number.
By their numbers in this assay, from the lowest: compound 1; then compounds 3, 2 and 4 (each within the scatter of the next).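

In this assay, placing (4H-1,2,4-triazol-3-yl)amino on the saturated chain carbon in place of the group with the five-membered non-aromatic ring gives a 10-fold higher number from compound 1 to compound 4 (1.00 log units; beyond the scatter). For the compounds shown here, this is the first single-change step, and it shows that the group held at this position alters the reading on an otherwise unchanged core, although compound 4 still gives 22 nM. Going by these compounds alone, the step covers several differences at once, with an aromatic ring replacing a non-aromatic one, an amino nitrogen as the link and different counts of hydrogen-bond donors and acceptors, so the single number cannot be divided among them.

Nothing measured here gives a reason for the size of this step.

Still open, as far as these compounds go, is whether the higher number follows the triazole ring or the amino link, a question that a pyrrolidinone joined through the same amino nitrogen, or a 1,2,4-triazole joined directly to the chain carbon, would address on this core. Also open, from the compounds shown here alone, is how a plain amine or a carboxylic acid on this carbon would read against compound 1.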